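The compounds below may be only part of what the source reports. "The series", "measured", "known", "first", "only" and "open" are said of these compounds alone.

In a functional assay on Daoy cells (Homo sapiens) for antiproliferative activity, read by trypan blue exclusion and crystal violet staining, with a stated time of 72 h (a lower number here means a stronger inhibitor, a higher number a weaker inhibitor), compound 2 `O=C(NCc1ccc2cccnc2c1O)C1CCCCC1` gives 720 nM. Compound 1 `CCCCOc1ccnc2c(O)c(CNC(=O)C3CCCCC3)ccc12` gives 510 nM, so the two lie within the scatter of each other. For compound 3 `CCCCC(=O)NCc1ccc2cccnc2c1O` the entry reads "nd" (no result reported), so it offers no comparison. Compound 4 `O=C(NCc1ccc2c(OCc3ccccc3)ccnc2c1O)C1CCCCC1` is still unmeasured. It has benzyloxy in place of hydrogen on an aromatic carbon opposite the ring nitrogen of compound 2 (benzyloxy in place of hydrogen on an aromatic carbon). Among the measured compounds shown here, the one measured step bearing on this change is a 1.4-fold higher number from compound 1 to compound 2 (0.15 log units; within the scatter), where hydrogen replaces butoxy on that same carbon, and it stays within the scatter. No step beyond the scatter is therefore expected in this assay. The expected step is a 1.4-fold lower number from compound 2 to compound 4 (0.16 log units; within the scatter). For compound 4 the estimated value is 500 nM, with an expected range of 200 nM to 1300 nM.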

Compound 4, half-maximal inhibitory concentration: 260 nM
Compound 4: the middle estimate sits 1.9-fold (0.28 log units) above what was measured, and the stated range covers the measured number.
By their numbers in this assay, from the lowest: compounds 4, 1 and 2 (each within the scatter of the next, the first and the last beyond it).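

In this assay, among the compounds shown here, benzyloxy on the aromatic carbon opposite the ring nitrogen gives a 2.8-fold lower number from compound 2 to compound 4 (0.44 log units; beyond the scatter), the first step at this position to pass beyond the scatter, so a group here can move the number measurably. Phenyl in place of propyl on the chain carbon bound to the oxygen gives a 2.0-fold lower number from compound 1 to compound 4 (0.29 log units; within the scatter), so benzyloxy and butoxy cannot be ranked. Nothing at hand explains why benzyloxy differs from hydrogen.

From the compounds shown here alone, whether a methoxy group, an amine or a carboxylic acid on this carbon would behave like benzyloxy stays open. So does whether substituents on the phenyl ring of benzyloxy would change the number.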